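From 4-aminobenzyl to 3-fluorobenzyl in a cytotoxicity test

The source may report more compounds than this note shows. Statements on the series, on what has been measured and on what is new or still open speak of the compounds shown alone.

Compound 1 (`COC(=O)c1ccc(NCc2cncn2Cc2ccc(N)cc2)cc1-c1ccccc1`) and compound 2 (`N#Cc1ccc(NCc2cncn2Cc2ccc(-c3ccccc3)cc2)cc1-c1ccccc1`) have both been tested, but neither gave an exact number. In a toxicity assay on NIH3T3 cells (Mus musculus) for cytotoxicity, read by resazurin assay (a higher number here means that more compound is needed for the effect, a lower number that less compound is needed), compound 1 gives > 10000 nM as a limit of the assay and not a number. Compound 2 gives > 1000 nM as a limit too. Compound 3 (`COC(=O)c1ccc(NCc2cncn2Cc2cccc(F)c2)cc1-c1ccccc1`) keeps the core of compound 1 and exchanges one group, with 3-fluorophenyl in place of 4-aminophenyl on a saturated chain carbon bound to an aromatic nitrogen. For the measured compounds named here, no measured step between related compounds is available as a guide, so the expectation rests on compound 1 and its limit of > 10000 nM alone. No shift beyond the usual scatter is expected in this assay and the estimated step that the limit leaves unreadable from compound 1 to compound 3 stays small. The expected value for compound 3 is 12000 nM with 3000 nM to 40000 nM as its estimated range.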

Compound 3, half-maximal effective concentration: > 1000 nM
Compound 3: a limit, no number; the forecaster's own chance of this, stated with the estimate: 60%; the middle value lies beyond the limit too.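

The step from compound 1 to compound 3 cannot be read, since in this assay each of the two compounds gives only a limit of the assay and not a number. The compounds shown leave open at what concentration any of them harms these cells, and whether exchanging 4-aminophenyl for 3-fluorophenyl changes that concentration.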